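This account rests on a few compounds, and the source may have more. Where it says the series, first, only, none or still open, it means among the compounds named here.

Measured in an in vitro functional assay on 1321-N1 cells for agonist activity at Free fatty acid receptor 1 (Homo sapiens), read by fluorescence, spectrophotometry and calcium flux; on this read-out higher numbers stand for an effect only at larger amounts of compound and lower numbers for an effect already at smaller amounts:

compound 1 `Cc1cc(C#Cc2ccc(CCC(=O)O)cc2)nc(Cl)n1` — 2750 nM
compound 2 `O=C(O)CCc1ccc(C#Cc2ncccc2[N+](=O)[O-])cc1` — 11000 nM
compound 3 `O=C(O)CCc1ccc(C#Cc2ccnc3cc(Cl)ccc23)cc1` — 79.4 nM

All three share the propanoic acid chain on a phenyl bearing an alkyne to a second aromatic ring. In this assay compound 2 stands at the highest number of the three; compound 1 sits nearest to it, with a gap that is beyond the usual scatter, and compound 3 sits furthest, far beyond the scatter.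

Compound 4 `O=C(O)CCc1ccc(C#Cc2ccccn2)cc1` is not yet measured. It differs from compound 2 in one place: hydrogen in place of nitro on an aromatic carbon — hydrogen in place of nitro on an aromatic carbon, the carbon ortho to the alkyne and two atoms from the ring nitrogen. Within the data shown here, no measured pair in this set shows the same change, so the size of the step cannot be read from a neighbouring pair; it can only be guessed from where compound 2 stands against compounds 1 and 3. Compound 2 carries the highest number shown, and the other two, which lack a nitro group, give lower numbers. The expectation for compound 4 is therefore a downward step in this assay, of a size beyond the scatter but modest, landing nearer to compound 1 than to compound 3. The estimated step is a 3.7-fold lower number from compound 2 to compound 4 (0.56 log units; beyond the scatter). For compound 4 the estimate is 3000 nM, within a range from 700 nM to 13000 nM.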

Compound 4, half-maximal effective concentration: 13200 nM
Compound 4: middle estimate off by 4.4-fold (0.64 log units), on the low side; measured number above the stated range.
By their numbers in this assay, from the lowest: compound 3; then compound 1; then compounds 2 and 4 (each within the scatter of the next).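

In this assay hydrogen in place of nitro on an aromatic carbon, ortho to a large group and two atoms from the ring nitrogen, gives a 1.2-fold higher number from compound 2 to compound 4 (0.08 log units; within the scatter) and so leaves the number where it was. On this pair the nitro group, with its 3 heavy atoms and 2 hydrogen-bond acceptors, can go from this carbon without a change that stands out from the scatter, so the high number of compound 2 cannot be laid on the nitro group. Nothing measured here gives a reason for this result.

Open, going by these compounds, is whether another group on this carbon, such as an amine, a methoxy group or a chlorine atom, would move the number. Among these compounds, no one-place pair links compound 4 to compound 1 or compound 3, so what separates their numbers stays unread.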